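Moving the fluorine on the piperazine aryl group

The source may hold more compounds than are shown below. What is called first, only, known or untested is meant among the compounds shown, and "the series" means these compounds.

Measured so far:
compound 1, `O=C(CCCCN1CCN(c2cccc(Cl)c2)CC1)Nc1ccccc1Cl`, 93.2%;
compound 2, `O=C(CCCN1CCN(c2ccccc2)CC1)Nc1ccc(Cl)cc1`, 75.1%;
compound 3, `O=C(CCCN1CCN(c2ccccc2F)CC1)Nc1ccc(Cl)cc1`, 79.2%.

In an assay on HEK293 cells for inhibition of Voltage-dependent T-type calcium channel subunit alpha-1G (Homo sapiens), read by patch clamp, tested at 10 uM (a lower number here means less inhibition, a higher number more inhibition at the concentration tested (going by the name of the read-out)), compound 3 stands second highest of the three numbers; its nearest neighbour is compound 2, within the scatter, while compound 1 lies beyond the scatter above it. Compound 4, `O=C(CCCN1CCN(c2ccc(F)cc2)CC1)Nc1ccc(Cl)cc1`, differs from compound 3 by 4-fluorophenyl in place of 2-fluorophenyl on an amine nitrogen in a ring. For the measured compounds named here, the only step that touches this position is a number 4.1 percentage points higher from compound 2 to compound 3 (within the scatter), which lay within the scatter, so the fluorine's presence itself hardly moved the number; no measured pair tells how its place on the ring matters. Compound 4 is therefore expected to stay close to compound 3, with a step of a number 1.2 percentage points lower from compound 3 to compound 4 (within the scatter), not beyond the scatter. The estimate for compound 4 is 78%, ranging from 63% to 91%.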

Compound 4, a percentage reported as inhibition, at one concentration (the size of the read-out at that concentration, not a potency): 76.1%
For compound 4 the middle estimate is 1.9 percentage points above the measured one, and the stated range covers the measured number.
By their numbers in this assay, from the lowest: compounds 2, 4 and 3 (each within the scatter of the next); then compound 1.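

In this assay the change from 2-fluorophenyl to 4-fluorophenyl gives a number 3.1 percentage points lower from compound 3 to compound 4 (within the scatter) and so the place of the fluorine on this aryl group does not separate the two compounds. The step of a number 1 percentage points higher from compound 2 to compound 4 (within the scatter) shows that 4-fluorophenyl, like 2-fluorophenyl, cannot be told from plain phenyl here. No evidence bears on this result. Still open, as far as these compounds go, is whether a methoxy or trifluoromethyl group on this aryl ring would move the number beyond the scatter. Also open, from the compounds shown here alone, is which of its several differences sets compound 1 apart.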